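From pyrrolidin-1-yl to 2,3-dihydro-1H-indol-1-yl on the thiocarbonyl carbon

The compounds below may be only part of what the source reports. "The series", "measured", "known", "first", "only" and "open" are said of these compounds alone.

compound 1 `COc1ccc(CN(C(=O)CSC(=S)N2CCN(C)CC2)c2cc(OC)c(OC)c(OC)c2)cc1`: 1250 nM
compound 2 `COc1ccc(CN(C(=O)CSC(=S)N2CCOCC2)c2cc(OC)c(OC)c(OC)c2)cc1`: 7220 nM
compound 3 `COc1ccc(CN(C(=O)CSC(=S)N2CCCC2)c2cc(OC)c(OC)c(OC)c2)cc1`: 13800 nM

In a functional assay on KYSE-450 cells (Homo sapiens) for inhibition, read by CCK-8 assay, with a stated time of 48 h (on this read-out lower numbers stand for stronger inhibition and higher numbers for weaker inhibition), compound 3 gives 13800 nM. That stands level with compound 2 at 7220 nM, as the gap is a 1.9-fold higher number from compound 2 to compound 3 (0.28 log units; within the scatter). Clear gaps separate both of them from the remaining compound: a 5.8-fold higher number from compound 1 to compound 2 (0.76 log units; beyond the scatter) and an 11-fold higher number from compound 1 to compound 3 (1.04 log units; beyond the scatter). These three compounds differ only in the ring on the thiocarbonyl carbon, while the shared core stays the same.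

The next compound, compound 4 `COc1ccc(CN(C(=O)CSC(=S)N2CCc3ccccc32)c2cc(OC)c(OC)c(OC)c2)cc1`, changes that ring again: 2,3-dihydro-1H-indol-1-yl in place of pyrrolidin-1-yl on a thiocarbonyl carbon. In words, 2,3-dihydro-1H-indol-1-yl replaces pyrrolidin-1-yl, which adds a six-membered aromatic ring of carbon only. Going by the values given here, none of the measured steps adds such a ring, so they offer only loose guidance. The large steps above all start from the 4-methylpiperazin-1-yl group of compound 1, and compound 4 lacks this group, as do compound 2 and compound 3. A step beyond the scatter in this assay is therefore not expected, in either direction, although the untested ring keeps the range wide.

The expected change is a 1.4-fold lower number from compound 3 to compound 4 (0.14 log units; within the scatter).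

For compound 4, the estimated value is 10000 nM, with an expected range from 3000 nM to 30000 nM.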

Compound 4, half-maximal inhibitory concentration: 6940 nM
The estimate for compound 4 lay 1.4-fold (0.16 log units) above the measured number, and the stated range covers the measured number.
By their numbers in this assay, from the lowest: compound 1; then compounds 4, 2 and 3 (each within the scatter of the next).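

In this assay, fusing a six-membered aromatic ring of carbon only onto the pyrrolidin-1-yl ring on the thiocarbonyl carbon gives a 2.0-fold lower number from compound 3 to compound 4 (0.30 log units; within the scatter), so this larger group leaves the result within the usual variation between repeats. Compound 4 also stands level with the morpholin-4-yl compound, with a 1.0-fold lower number from compound 2 to compound 4 (0.02 log units; within the scatter), but it remains apart from the 4-methylpiperazin-1-yl compound, with a 5.6-fold higher number from compound 1 to compound 4 (0.74 log units; beyond the scatter), which makes compound 1 the only one of the four set clearly apart and the most potent in this set. No measurement accompanying these results explains this pattern.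

The compounds shown leave open which feature of the 4-methylpiperazin-1-yl ring sets compound 1 apart, since a piperidin-1-yl ring would show what happens when a ring carbon takes the place of the methyl-bearing nitrogen. A piperazin-1-yl ring with a free amine, or a 4-ethylpiperazin-1-yl ring with a longer chain on that nitrogen, would show whether the methyl group itself matters.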